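The source may hold more compounds than are shown below. What is called first, only, known or untested is meant among the compounds shown, and "the series" means these compounds.

Measured compounds:
- Compound 1, `COc1ccccc1N1CCN(C[C@H](O)COc2ccc(Cl)cc2)CC1`, in an assay on HEK293 cells for inhibition of Voltage-dependent T-type calcium channel subunit alpha-1G (Homo sapiens), read by patch clamp, tested at 10 uM (on this read-out higher numbers stand for more inhibition at the one concentration tested (going by the name of the read-out) and lower numbers for less inhibition), gives 48.8%.
- Compound 2, `COc1ccccc1N1CCN(C[C@@H](O)COc2ccc(F)cc2)CC1`, in this assay gives 50.7%.
- Compound 3, `O[C@H](COc1ccc(F)cc1)CN1CCN(c2ccc(F)cc2)CC1`, in this assay gives 50%.

The three measured compounds share a core and differ in the aryl group on the piperazine nitrogen and in the halogen and configuration on the aryloxy side. Their three values sit close together: the gap between compound 3 and compound 2 lies within the usual scatter, and so does the gap between compound 3 and compound 1. On the numbers shown, compound 3 cannot be told apart from either of the other two in this assay.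

Compound 4, `COc1ccccc1N1CCN(C[C@H](O)COc2ccc(F)cc2)CC1`, is not yet measured. It differs from compound 3 in one place: 2-methoxyphenyl in place of 4-fluorophenyl on an amine nitrogen in a ring. The same 2-methoxyphenyl group on the ring nitrogen is already present in compound 1 and compound 2, and neither of those stands apart from compound 3 in this assay.

Since the three compounds give values within scatter of one another, the step from compound 3 to compound 4 is expected to be no change at the digits printed from compound 3 to compound 4 (within the scatter), that is, no change beyond the scatter in either direction. Compound 4 is therefore expected to give about 50% in this assay, most likely between 40% and 60%.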

Compound 4, a percentage reported as inhibition, at one concentration (the size of the read-out at that concentration, not a potency): 41%
Beside the measured number, compound 4's estimate is 9 percentage points above it; the range from low to high includes it.
By their numbers in this assay, from the lowest: compounds 4, 1, 3 and 2 (each within the scatter of the next).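

In this assay, 2-methoxyphenyl in place of 4-fluorophenyl on an amine nitrogen in a ring gives a number 9 percentage points lower from compound 3 to compound 4 (within the scatter), so this exchange, now readable as a single step, has no effect that can be told from the scatter. Fluoro in place of chloro on an aromatic carbon gives a number 7.8 percentage points lower from compound 1 to compound 4 (within the scatter), and a stereocentre at a saturated chain carbon drawn the other way gives a number 9.7 percentage points lower from compound 2 to compound 4 (within the scatter), so neither of these two changes stands out from the scatter either. The reading on configuration is a direct one, but it rests on a single pair: the fact that compounds 2 and 4 differ only in the configuration as drawn.

The compounds shown leave open whether a group of another kind on the same ring nitrogen, such as a benzyl group or a longer chain ending in an amine, would move the number beyond the scatter. Since each value comes from one concentration, they also leave open whether full concentration-response measurements would separate these compounds in potency.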